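This account rests on a few compounds, and the source may have more. Where it says the series, first, only, none or still open, it means among the compounds named here.

Compound 2 `O=C(Nc1ccccc1)c1cc(F)ccc1O` is the plain member of this small set. In a functional assay on HL-60 cells (Homo sapiens) for cytotoxicity, read by luminescence and CellTiter-Glo, with a stated time of 3 days (a lower number here means a stronger inhibitor, a higher number a weaker inhibitor), compound 2 gives > 10000 nM, which is a limit of the assay rather than a number (the limit of > 10000 nM in this assay, at which 1 of the 3 values shown sits). Two close relatives carry a substituent on the aniline ring. Compound 1 `O=C(Nc1ccc(OC(F)(F)F)cc1)c1cc(F)ccc1O` gives 850 nM in this assay, and compound 3 `N#Cc1ccc(NC(=O)c2cc(F)ccc2O)cc1` gives 1420 nM. The step of an at least 11-fold higher number from compound 1 to compound 2 (1.07 log units; beyond the scatter) and the step of an at least 7.0-fold lower number from compound 2 to compound 3 (0.84 log units; beyond the scatter) both show that adding a group to that ring moves the number sharply downward, while the step of a 1.7-fold higher number from compound 1 to compound 3 (0.22 log units; within the scatter) shows the two substituents themselves sit within the scatter of each other.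

Compound 4 `O=C(Nc1cccc(OC(F)(F)F)c1)c1cc(F)ccc1O` makes a change of the same kind, though at a different spot: trifluoromethoxy in place of hydrogen on an aromatic carbon. Since the same group at another position gave compound 1 its value 850 nM, a step of an at least 6.6-fold lower number from compound 2 to compound 4 (0.82 log units; beyond the scatter) downward is expected, though a weaker one than in compound 1 is allowed for. Compound 4 is therefore estimated at 1500 nM, with a range from 500 nM to 6000 nM.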

Compound 4, half-maximal inhibitory concentration: 730 nM
The estimate for compound 4 lay 2.1-fold (0.31 log units) above the measured number, within the range that was stated.
By their numbers in this assay, from the lowest: compounds 4, 1 and 3 (each within the scatter of the next). At a limit, above all of these: compound 2.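

Trifluoromethoxy in place of hydrogen, meta to a large group, gives an at least 13-fold lower number from compound 2 to compound 4 (1.13 log units; beyond the scatter), so in these two compounds the drop that came with this group in compound 1 is not tied to a single position. In this assay compound 4 gives 730 nM and compound 1 gives 850 nM, values within the scatter of each other, so the two placements of the group cannot be told apart here. The true size of the step stays unknown, because compound 2 stands at a limit of the assay and not at a number: the limit of > 10000 nM in this assay, at which 1 of the 4 values shown sits.

Among these compounds, still open is whether a nitrile at this same position would behave like the one in compound 3. Also open, as far as these compounds go, is whether an amine or a carboxylic acid placed here would keep the number as low.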